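Removing a Methoxy Group from a Hydroxamic Acid Triazole

The compounds below may be only part of what the source reports. "The series", "measured", "known", "first", "only" and "open" are said of these compounds alone.

Measured compounds:
compound 1, `COc1ccc(-n2nc(-c3ccccc3)nc2CNc2ccc(C(=O)NO)cc2)cc1`: 63.4%
compound 2, `O=C(NO)c1ccc(NCc2nc(-c3cccnc3)nn2-c2ccccc2)cc1`: 57.7%
compound 3, `O=C(NO)c1ccc(NCc2nc(-c3ccc(Cl)cc3)nn2-c2ccccc2)cc1`: 67.2%

Of the compounds shown here, three sharing the same core have been tested in an assay on Sf9 cells for inhibition of protein deacetylase HDAC6 (Homo sapiens), read by fluorescence, with a stated time of 40 min, tested at 100 nM; a higher number here means more inhibition at the concentration tested (going by the name of the read-out), a lower number less inhibition. Compound 1 gives 63.4%, compound 2 gives 57.7%, and compound 3 gives 67.2%. All three numbers lie within the usual scatter of one another, so compound 1 cannot be set apart from the rest: its nearest neighbour is compound 3 and its furthest is compound 2, and both gaps are within the scatter.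

Among the measured compounds shown here, the only measured step, a number 9.5 percentage points higher from compound 2 to compound 3 (within the scatter), swaps the group on the triazole carbon and is itself within the scatter. It says nothing directly about the change now considered, which sits on the other ring of compound 1: hydrogen in place of methoxy on an aromatic carbon, giving compound 4, `O=C(NO)c1ccc(NCc2nc(-c3ccccc3)nn2-c2ccccc2)cc1`.

For the measured compounds named here, no measured pair alters this position, so the expectation rests only on the flat picture across compounds 1, 2 and 3, where every change so far stayed within the scatter. The step of a number 1.4 percentage points lower from compound 1 to compound 4 (within the scatter) is therefore expected to be small, with no clear direction. Compound 4 is estimated at 62%, within a range from 48% to 76%.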

Compound 4, a percentage reported as inhibition, at one concentration (the size of the read-out at that concentration, not a potency): 72.6%
Compound 4: middle estimate off by 10.6 percentage points, on the low side; measured number inside the range.
By their numbers in this assay, from the lowest: compounds 2, 1, 3 and 4 (each within the scatter of the next, the first and the last beyond it).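

Replacing the methoxy group with hydrogen, which turns the 4-methoxyphenyl into a phenyl, gives a number 9.2 percentage points higher from compound 1 to compound 4 (within the scatter) in this assay, so inhibition at this place on the shared core does not depend on the methoxy group. Compound 4 also puts the earlier flat picture in a new light: hydrogen in place of chloro gives a number 5.4 percentage points higher from compound 3 to compound 4 (within the scatter), while phenyl in place of pyridin-3-yl gives a number 14.9 percentage points higher from compound 2 to compound 4 (beyond the scatter), a modest step and the first in this small set that stands clear of the usual scatter. Nothing at hand explains why any of these steps has the size it has.

The compounds shown compare only methoxy and hydrogen at the place on the ring that compound 1 changes, so it remains open whether an amine, a carboxylic acid or a longer chain such as butoxy would leave inhibition at a similar level or lower it. Each number is also the size of the read-out at a single concentration, so the order of these compounds by true potency remains open too.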